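This account rests on a few compounds, and the source may have more. Where it says the series, first, only, none or still open, it means among the compounds named here.

Compound 1 `COc1ccc(CN(C(C)=O)c2cc(OC)c(OC)c(OC)c2)cc1O` carries an acetyl on the shared core. In a functional assay on HCT-116 cells (Homo sapiens) for inhibition, read by MTT assay, with a stated time of 48 h (a lower number here means a stronger inhibitor, a higher number a weaker inhibitor), compound 1 gives 270 nM, the lowest of the two numbers recorded here. Going by the values given here, the only other measured compound, compound 2 `C/C=C/C(=O)N(Cc1ccc(OC)c(OC)c1)c1cc(OC)c(OC)c(OC)c1`, gives 32800 nM in this assay, a much higher number; since it differs from compound 1 in more than one place, no single step can be read from that pair. Among the compounds with values here, compound 3 `COc1ccc(CN(C(=O)CN=[N+]=[N-])c2cc(OC)c(OC)c(OC)c2)cc1O` is the one compound not yet measured. It differs from compound 1 in a single place: azido in place of hydrogen on a saturated chain carbon bound to a carbonyl carbon. Within the data shown here, no step between measured compounds covers such a change, so the expectation rests on compound 1 alone. Compound 3 is expected to stay near compound 1, with a step of a 1.9-fold higher number from compound 1 to compound 3 (0.27 log units; within the scatter) that is small, if anything toward a higher number, and perhaps no larger than the scatter. Compound 3 is therefore estimated at 500 nM, within 150 nM to 2000 nM.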

Compound 3, half-maximal inhibitory concentration: 410 nM
For compound 3 the middle estimate is 1.2-fold (0.09 log units) above the measured one; the range from low to high includes it.
By their numbers in this assay, from the lowest: compounds 1 and 3 (each within the scatter of the next); then compound 2.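

In this assay, going by these compounds alone, putting azido in place of hydrogen on a saturated chain carbon bound to a carbonyl carbon gives a 1.5-fold higher number from compound 1 to compound 3 (0.18 log units; within the scatter), the first single-place step that can be read at this position. The earlier pair could not show this, but the new step shows that the acetyl of compound 1 can become (azidomethyl)carbonyl without the value leaving the scatter, so this one substitution does not separate compound 1 from compound 3 in this assay. Nothing available bears on the reason for this result.

Among the compounds shown, azido is the only group added at this carbon, so it remains open whether an amine, a carboxylic acid or a longer chain there would also stay within the scatter of compound 1. Compound 2 differs from compound 1 in more than one place, so the compounds shown do not separate the contribution of its butenoyl group from that of its other differences.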